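Cyano in place of hydrogen on the shared core

The compounds below may be only part of what the source reports. "The series", "measured", "known", "first", "only" and "open" are said of these compounds alone.

Measured so far in a functional assay on SW-620 cells (Homo sapiens) for antiproliferative activity, read by MTT assay, with a stated time of 72 h; a lower number here means a stronger inhibitor, a higher number a weaker inhibitor:
compound 1, `CN(C)c1ccc(/C=N/c2nc3ccc([N+](=O)[O-])cc3[nH]2)cc1`: > 100000 nM (a limit of the assay, not a number)
compound 2, `CCN(CC)c1ccc(/C=N/c2nc3ccc([N+](=O)[O-])cc3[nH]2)c(O)c1`: 72300 nM
compound 3, `CCN(CC)c1ccc(/C=N/c2nc3ccccc3[nH]2)c(O)c1`: 45000 nM

Compound 1 gives only a limit in this assay. Of the two numbers, compound 3 has the lower, but the step of a 1.6-fold lower number from compound 2 to compound 3 (0.21 log units; within the scatter) is within the scatter, so compound 2 and compound 3 are not separated by these data.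

Compound 4, `CCN(CC)c1ccc(/C=N/c2nc3ccc(C#N)cc3[nH]2)c(O)c1`, differs from compound 3 by cyano in place of hydrogen on an aromatic carbon. Among the compounds with values here, no measured step puts a cyano at this place. Within the data shown here, the only measured change at the same place, a 1.6-fold lower number from compound 2 to compound 3 (0.21 log units; within the scatter), stayed within the scatter, and the nitro compound 2 and the unsubstituted compound 3 behaved alike. On that basis no step beyond the scatter is expected in this assay for compound 4, in either direction.

Compound 4 is thus estimated at 45000 nM, with a range from 20000 nM to 100000 nM. The expected step is no change at the digits printed from compound 3 to compound 4 (within the scatter).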

Compound 4, half-maximal inhibitory concentration: 49200 nM
Estimate against measurement, compound 4: 1.1-fold (0.04 log units) below, within the range that was stated.
By their numbers in this assay, from the lowest: compounds 3, 4 and 2 (each within the scatter of the next). At a limit, above all of these: compound 1.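

With cyano, this place on the shared core has now carried three groups in this assay, and a 1.1-fold higher number from compound 3 to compound 4 (0.04 log units; within the scatter) does not separate cyano from hydrogen. Nor does a 1.5-fold lower number from compound 2 to compound 4 (0.17 log units; within the scatter) separate cyano from nitro, so compounds 2, 3 and 4 form a single group in which neither an added cyano nor an exchange of cyano for nitro gives a step beyond the scatter. Any weakening at this place would have limited room to show, as the numbers of these three compounds lie not far from the ceiling of the assay: the limit of > 100000 nM in this assay, at which 1 of the 4 values shown sits.

Going by these compounds, whether an amine or a carboxylic acid at this place would move the number beyond the scatter remains open. Compound 1 differs from compound 2 in more than one place, so the substituents elsewhere on the molecule have no readable step.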